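Aryl substituent changes on a shared carbamoyl benzoxazolone core

A few compounds are considered here, and "the series" means these few. Any claim that something is new, unique, unknown or untested is made for them only; others in the source may bear on it.

Measured compounds:
- compound 1, `COc1ccc(-c2ccc3c(c2)oc(=O)n3C(=O)NCCCCc2ccccc2)cc1`: 67 nM
- compound 2, `O=C(c1ccc(Cl)cc1)c1ccc2c(c1)oc(=O)n2C(=O)NCCCCc1ccccc1`: 14 nM

Going by the values given here, in an assay on HEK293 cells for inhibition of acid ceramidase (Homo sapiens), with a stated time of 10 min (on this read-out higher numbers stand for weaker inhibition and lower numbers for stronger inhibition), compound 2 gives 14 nM and stands at the lowest of the two numbers so far. Its nearest neighbour is compound 1, which in this assay gives 67 nM; the step of a 4.8-fold lower number from compound 1 to compound 2 (0.68 log units; beyond the scatter) is the only one measured and it lies beyond the scatter.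

Compound 3, `O=C(NCCCCc1ccccc1)n1c(=O)oc2cc(-c3ccccc3)ccc21`, is not yet measured. It differs from compound 2 in one place: phenyl in place of (4-chlorophenyl)carbonyl on an aromatic carbon. Among the compounds with values here, the only measured step that touches this position is a 4.8-fold lower number from compound 1 to compound 2 (0.68 log units; beyond the scatter), where a (4-chlorophenyl)carbonyl replaced a 4-methoxyphenyl. Compound 3 carries a bare phenyl, closer in size to the group of compound 1 than to that of compound 2, so the expectation is that compound 3 gives up part of what compound 2 gained, with a step of about a 3.6-fold higher number from compound 2 to compound 3 (0.55 log units; beyond the scatter) toward a higher number. The estimate for compound 3 in this assay is 50 nM, with a range from 15 nM to 170 nM.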

Compound 3, half-maximal inhibitory concentration in the acid ceramidase assay: 84 nM
Beside the measured number, compound 3's estimate is 1.7-fold (0.23 log units) below it; low and high end bracket the measured number.
By their numbers in the acid ceramidase assay, from the lowest: compound 2; then compounds 1 and 3 (each within the scatter of the next).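

In the acid ceramidase assay, phenyl in place of (4-chlorophenyl)carbonyl on an aromatic carbon gives a 6.0-fold higher number from compound 2 to compound 3 (0.78 log units; beyond the scatter), so an aromatic ring at this place is not enough on its own to reach the low number of compound 2 (14 nM). Hydrogen in place of methoxy on an aromatic carbon gives a 1.3-fold higher number from compound 1 to compound 3 (0.10 log units; within the scatter), so this pair shows no readable difference for the methoxy, and the gap seen at this position goes with the (4-chlorophenyl)carbonyl group in compound 2 among the three compounds shown. In a physicochemical assay for metabolic stability, read by HPLC, in phosphate buffer, at pH 7.4, tested at 10 uM (a higher number here means that the compound lasts longer, a lower number that the compound disappears faster), compound 2 gives 4.57 h. In the physicochemical assay compound 3 gives > 5 h, which is a limit of the assay and not a number, so the step on this read-out cannot be read: the limit of > 5 h in the physicochemical assay, at which 1 of the 2 values shown sits.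

Open, on these data alone, is whether the carbonyl or the chlorine goes with the lower number of compound 2, since the two occur together here; a benzoyl group without the chlorine and a 4-chlorophenyl group without the carbonyl would separate them. Also open, as far as these compounds go, is how a carboxylic acid or an amine on the same aromatic carbon would read in the acid ceramidase assay.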